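Isopropyl carbamate series: aryl exchange on the fused ring nitrogen

The source may hold more compounds than are shown below. What is called first, only, known or untested is meant among the compounds shown, and "the series" means these compounds.

In a functional assay on CHO-K1 cells for agonist activity at Glucose-dependent insulinotropic receptor (Homo sapiens), read by a luciferase reporter, with a stated time of 5 h (on this read-out lower numbers stand for an effect already at smaller amounts and higher numbers for an effect only at larger amounts of compound), compound 1 `CC(C)(C)OC(=O)N1CCC(Oc2ncnc3c2CCN3c2ccc(S(C)(=O)=O)cc2F)CC1` gives 20 nM, and compound 2 `CC(C)OC(=O)N1CCC(Oc2ncnc3c2CCN3c2ccc(S(C)(=O)=O)nc2)CC1` gives 251 nM. Compound 2 therefore carries the higher of the two numbers, and its gap to compound 1 lies beyond the scatter of such measurements. Compound 3 `CC(C)OC(=O)N1CCC(Oc2ncnc3c2CCN3c2ccc([S@+](C)[O-])c(F)c2)CC1` differs from compound 2 in one place: a group of 10 heavy atoms (7 carbon, 1 oxygen, 1 fluorine, 1 sulfur; one six-membered aromatic ring of carbon only) in place of a group of 10 heavy atoms (6 carbon, 1 nitrogen, 2 oxygen, 1 sulfur; one six-membered aromatic ring with 1 hetero atom), on a nitrogen on an aromatic ring in a ring. Among the compounds with values here, no measured pair traces this exact exchange; the expectation leans on compound 1, which gives 20 nM with a six-membered aromatic ring of carbon only on that nitrogen. Compound 3 is estimated at 80 nM, within 20 nM to 320 nM. The expected step of a 3.1-fold lower number from compound 2 to compound 3 (0.50 log units; beyond the scatter) points to a lower number, beyond the scatter.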

Compound 3, half-maximal effective concentration: 50.1 nM
Beside the measured number, compound 3's estimate is 1.6-fold (0.20 log units) above it; low and high end bracket the measured number.
By their numbers in this assay, from the lowest: compound 1; then compound 3; then compound 2.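

In this assay, within the data shown here, the exchange on the nitrogen gives a 5.0-fold lower number from compound 2 to compound 3 (0.70 log units; beyond the scatter), the first measured step at this position. It shows that the 6-(methylsulfonyl)pyridin-3-yl group can give way to an aromatic ring of carbon only, carrying fluorine and a sulfur group with a defined stereocentre, with a gain on this read-out. The ring, fluorine and sulfur group all change together, and nothing available explains the step.

The compounds shown do not separate these three changes. They also leave open the opposite configuration at the stereocentre and whether a nitrile could replace the sulfur group.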